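A few compounds are considered here, and "the series" means these few. Any claim that something is new, unique, unknown or untested is made for them only; others in the source may bear on it.

Measured so far in an ADME assay on HEK293 cells (Homo sapiens) for cytotoxicity, with a stated time of 72 h; a higher number here means that more compound is needed for the effect, a lower number that less compound is needed:
compound 1 `Cc1cc(NC(=O)Nc2cccc(C(N)=O)c2)c2ccccc2n1`: > 25000 nM (a limit of the assay, not a number)
compound 2 `Cc1cc(NC(=O)Nc2cccc(C(F)(F)F)c2)c2ccccc2n1`: 16000 nM

Among the compounds with values here, compound 2 holds the only true number so far. The other reading is the limit of > 25000 nM in this assay, at which 1 of the 2 values shown sits, and it belongs to compound 1. The single measured step is an at least 1.5-fold lower number from compound 1 to compound 2 (0.19 log units; that floor lies within the scatter), so even this step, which brings in the trifluoromethyl group of compound 2, is not shown to exceed the scatter.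

Compound 3 `COc1cccc(NC(=O)Nc2cc(C)nc3ccccc23)c1` is still to be measured in this assay. Its change is methoxy in place of trifluoromethyl on an aromatic carbon, meta to a large group. Within the data shown here, only the step to compound 2 bears on this change, and it involves a different incoming group, so it offers weak guidance. No step beyond the scatter is therefore expected, with a slight lean towards a higher number, and the estimated step is a 1.3-fold higher number from compound 2 to compound 3 (0.10 log units; within the scatter). A reading at the limit of the assay would also not be unexpected. For compound 3 the estimated value is 20000 nM, with an expected range of 10000 nM to 35000 nM.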

Compound 3, half-maximal effective concentration: > 25000 nM
Compound 3 ended at the assay's limit (the forecaster's own chance of this, stated with the estimate: 35%); middle value at least 1.2-fold (0.09 log units) from the limit.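

With methoxy in this assay, the position on the aromatic carbon, meta to a large group, has now carried three groups, and only trifluoromethyl gives a true number. Methoxy in place of trifluoromethyl gives an at least 1.5-fold higher number from compound 2 to compound 3 (0.19 log units; that floor lies within the scatter), so this change is not shown to exceed the scatter, and the real size of the step remains undetermined. The steps between the two compounds at the limit cannot be read, and the series now has more limits than true numbers: the limit of > 25000 nM in this assay, at which 2 of the 3 values shown sit.

Still open, on these data alone, is how far compound 1 and compound 3 lie past the limit, and so whether carbamoyl and methoxy differ from each other at all in this assay. As far as these compounds go, it is also open whether trifluoromethyl stands alone at this position or whether a chlorine atom, an amine or a carboxylic acid on the same aromatic carbon would also give a true number, and whether any such group would move the reading beyond the scatter from that of compound 2.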